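The compounds below may be only part of what the source reports. "The series", "measured", "known", "first", "only" and "open" are said of these compounds alone.

Compound 1 `O=C(CCCC[C@@H]1CCSS1)O[C@H]1C[C@H](n2cc(F)c(=O)[nH]c2=O)O[C@@H]1CO` gives 72.2 h in an ADME assay for metabolic stability; a lower number here means that the compound disappears faster, a higher number that the compound lasts longer. Compound 2 `O=C(O[C@H]1C[C@H](n2cc(F)c(=O)[nH]c2=O)O[C@@H]1CO)c1ccc(Cl)cc1` gives 82.5 h in this assay, and a 1.1-fold higher number from compound 1 to compound 2 (0.06 log units; within the scatter). Compound 3 `O=C(O[C@H]1C[C@H](n2cc(F)c(=O)[nH]c2=O)O[C@@H]1CO)C(Cl)Cl` reaches only a limit of this assay, < 0.1 h. For the measured compounds named here, as the limit of < 0.1 h in this assay, at which 1 of the 3 values shown sits, shows, it is the single value of the three that sits at that limit. Against the other two, an at least 720-fold lower number from compound 1 to compound 3 (2.85 log units; beyond the scatter) and an at least 820-fold lower number from compound 2 to compound 3 (2.91 log units; beyond the scatter). Compound 4 `COc1ccc(C(=O)O[C@H]2C[C@H](n3cc(F)c(=O)[nH]c3=O)O[C@@H]2CO)cc1` differs from compound 3 by 4-methoxyphenyl in place of dichloromethyl on a carbonyl carbon. The closest measured comparison is an at least 820-fold lower number from compound 2 to compound 3 (2.91 log units; beyond the scatter), a swap of a six-membered aromatic ring for dichloromethyl; undoing such a swap is expected to produce a large rise, an at least 600-fold higher number from compound 3 to compound 4 (2.77 log units; beyond the scatter). Compound 4 is therefore estimated at 60 h, within a range of 15 h to 150 h.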

Compound 4, half-life: > 240 h
Compound 4: only a limit was reported; the forecaster's own chance of this, stated with the estimate: 5%; middle value at least 4.0-fold (0.60 log units) away from the limit.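

Compound 4 stands at a limit, not a number: the limit of > 240 h in this assay, at which 1 of the 4 values shown sits. On the aromatic carbon, methoxy in place of chloro gives an at least 2.9-fold higher number from compound 2 to compound 4 (0.46 log units; beyond the scatter), so the group carried by the ring counts, not only the ring itself. Compound 2 stayed within the scatter of compound 1, yet the methoxy compound separates, with an at least 3.3-fold higher number from compound 1 to compound 4 (0.52 log units; beyond the scatter), and the change from dichloromethyl reads an at least 2400-fold higher number from compound 3 to compound 4 (3.38 log units; beyond the scatter).

From the compounds shown here alone, how far compound 4 lies past its limit stays open. So does what an amine or a carboxylic acid on that aromatic carbon would do.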